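The compounds below may be only part of what the source reports. "The series", "measured", "known", "first", "only" and "open" are said of these compounds alone.

Series notes, cytotoxicity read-out. All values are from a functional assay on SH-SY5Y cells (Homo sapiens) for cytotoxicity, read by MTT assay, with stated times of 24 h and 4 h; on this read-out lower numbers stand for an effect already at smaller amounts and higher numbers for an effect only at larger amounts of compound.

Measured so far:
- compound 1, `COc1cc(CNC(=O)/C=C/c2ccccc2O)ccc1O`: compound 1 gives 9760 nM
- compound 2, `COc1cc(CNC(=O)/C=C/c2ccccc2OCc2nc(C)c(C)nc2C)ccc1O`: compound 2 gives 12000 nM
- compound 3, `COc1cc(/C=C/C(=O)NCc2ccc(O)c(OC)c2)cc(OC)c1`: compound 3 gives 4860 nM

Compound 2 differs from compound 1 in one place, ((3,5,6-trimethylpyrazin-2-yl)methyl in place of hydrogen on an oxygen on an aromatic ring). The step that this change made is a 1.2-fold higher number from compound 1 to compound 2 (0.09 log units; within the scatter), so within this pair the (3,5,6-trimethylpyrazin-2-yl)methyl group on the aromatic oxygen leaves the number essentially where it was. Compound 3 carries a different core; the difference between the core of compound 1 and the core of compound 3 is not broken down here. Its number stands at the low end of the three, within the scatter of compound 1 and beyond the scatter only against compound 2.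

Not yet measured is compound 4, `COc1cc(/C=C/C(=O)NCc2ccc(OCc3nc(C)c(C)nc3C)c(OC)c2)cc(OC)c1`. It differs from compound 3 by (3,5,6-trimethylpyrazin-2-yl)methyl in place of hydrogen on an oxygen on an aromatic ring, the same change that separates compound 2 from compound 1; the two place descriptions agree word for word, and the change occurs twice among the compounds shown. Since this change, measured once, gave a 1.2-fold higher number from compound 1 to compound 2 (0.09 log units; within the scatter), the expectation for the second occurrence is a step of similar size, a 1.2-fold higher number from compound 3 to compound 4 (0.08 log units; within the scatter), resting only on that single precedent. Compound 4 is therefore estimated at 5800 nM in this assay, with an expected range from 2600 nM to 13000 nM, the width reflecting that the step rests on one pair and that the two cores differ.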

Compound 4, half-maximal effective concentration: 8660 nM
Estimate against measurement, compound 4: 1.5-fold (0.17 log units) below; the range from low to high includes it.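

In this assay, the (3,5,6-trimethylpyrazin-2-yl)methyl group in place of hydrogen on the aromatic oxygen now gives a 1.8-fold higher number from compound 3 to compound 4 (0.25 log units; within the scatter), and the second occurrence does not differ from the first: the same change on two cores in this assay, a 1.2-fold higher number (0.09 log units; within the scatter) from compound 1 to compound 2 and a 1.8-fold higher number (0.25 log units; within the scatter) from compound 3 to compound 4, 1.4-fold (0.16 log units) apart, within the scatter of two such steps. On the two cores shown, hydroxy to (3,5,6-trimethylpyrazin-2-yl)methoxy therefore leaves the number essentially where it was, and the core of compound 1 and the core of compound 3 give no sign of treating this change differently. This does not establish a fixed size or a real direction for the step, since neither step lies beyond the scatter, and two pairs in a single cytotoxicity read-out say nothing about how the change behaves on any other core.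

The compounds shown leave open whether the same near-absence of a step would hold on a third core, and whether it is particular to the (3,5,6-trimethylpyrazin-2-yl)methyl group. A simple benzyl group, a longer alkyl chain, or a chain ending in an amine or a carboxylic acid on the same oxygen could show whether this position tolerates substitution in general in this assay.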